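Thiophene in place of methoxyphenyl on a shared aminoimidazole core

This account rests on a few compounds, and the source may have more. Where it says the series, first, only, none or still open, it means among the compounds named here.

Measured compounds in an ADME assay on HUVEC cells (Homo sapiens) for cytotoxicity, read by MTT assay, with a stated time of 48 h; on this read-out lower numbers stand for stronger inhibition and higher numbers for weaker inhibition:
Compound 1 `Cc1ccc(-c2cn(/N=C/c3cc4ccccc4nc3Cl)c(N)n2)cc1` gives a limit of > 50000 nM, which is a limit of this assay and not a number.
Compound 2 `COc1ccc(-c2cn(/N=C/c3cc4ccccc4nc3Cl)c(N)n2)cc1` gives 12400 nM.
Compound 3 `COc1ccc(-c2cn(/N=C/c3cc4cc(C)ccc4nc3Cl)c(N)n2)cc1` gives 12200 nM.

Among the two numbers, compound 2 gives the highest, and compound 3 sits within the scatter of it. The step of an at least 4.0-fold lower number from compound 1 to compound 2 (0.60 log units; beyond the scatter) is the only one beyond the scatter; the step of a 1.0-fold lower number from compound 2 to compound 3 (0.01 log units; within the scatter) is not. Compound 4 `Nc1nc(-c2cccs2)cn1/N=C/c1cc2ccccc2nc1Cl` differs from compound 2 in the change (thiophen-2-yl in place of 4-methoxyphenyl on an aromatic carbon). Among the compounds with values here, no measured step changes the aromatic group at this place, so the two steps bear on it only loosely: the step from compound 1 to compound 2 shows that the group here can move this assay, while the step from compound 2 to compound 3 shows a change elsewhere can leave it unchanged. Compound 4 is expected near compound 2, with a step of a 1.5-fold higher number from compound 2 to compound 4 (0.16 log units; within the scatter) not clearly beyond the scatter, at an estimated 18000 nM with a range from 6000 nM to 50000 nM.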

Compound 4, half-maximal inhibitory concentration: 10200 nM
Beside the measured number, compound 4's estimate is 1.8-fold (0.25 log units) above it; the range from low to high includes it.
By their numbers in this assay, from the lowest: compounds 4, 3 and 2 (each within the scatter of the next). At a limit, above all of these: compound 1.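

In this assay, within the data shown here, the first change of the whole aromatic group at this place, from 4-methoxyphenyl to thiophen-2-yl, gives a 1.2-fold lower number from compound 2 to compound 4 (0.08 log units; within the scatter), so a five-membered aromatic ring with sulfur and a six-membered carbon ring read alike here. Thiophen-2-yl in place of 4-methylphenyl gives an at least 4.9-fold lower number from compound 1 to compound 4 (0.69 log units; beyond the scatter), which leaves 4-methylphenyl apart from the other two groups at this place, though that step rests on a limit and not a number: the limit of > 50000 nM in this assay, at which 1 of the 4 values shown sits.

Still open, on these data alone, is how an amine or a carboxylic acid on the aromatic group would read here. As far as these compounds go, whether a saturated ring such as piperidine in place of the aromatic group would read differently is also open.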